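Working notes on chain homologation and tolerated concentration

The compounds below may be only part of what the source reports. "The series", "measured", "known", "first", "only" and "open" are said of these compounds alone.

Values in the list below come from an ADME assay on HepG2 cells (Homo sapiens) for cytotoxicity, read by XTT assay, with a stated time of 48 h; a lower number here means that less compound is tolerated, a higher number that more compound is tolerated.

compound 1, `CCCCCCCCCC[C@@H]1CC(O)=C(C(=O)CCC)C(=O)O1`: 25 ug/mL
compound 2, `CCCCCCCCCCC[C@@H]1CC(O)=C(C(=O)CCC)C(=O)O1`: 19 ug/mL
compound 3, `CCCCCCCCC[C@@H]1CC(O)=C(C(=O)CCCC)C(=O)O1`: 36 ug/mL

Compounds 1 and 2 differ by one change, (methyl in place of hydrogen on a saturated chain carbon, ten or more bonds along the chain from a saturated ring carbon). In this assay the step is a 1.3-fold lower number from compound 1 to compound 2 (0.12 log units; within the scatter), so the two values cannot be told apart by this assay. Compound 3 has the same atoms as compound 1 joined differently; the difference between the two cores is not broken down here. Compound 3 stands within the scatter of both compound 1 and compound 2 in this assay, so no order among the three is established.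

Compound 4, `CCCCCCCCC[C@@H]1CC(O)=C(C(=O)CCCCC)C(=O)O1`, is not yet measured. It differs from compound 3 by methyl in place of hydrogen on a saturated chain carbon, four bonds along the chain from a carbonyl carbon. This is the same kind of change as that from compound 1 to compound 2, but not the same: there the methyl enters on a saturated chain carbon placed relative to a saturated ring carbon, whereas here it enters on a saturated chain carbon four bonds along the chain from a carbonyl carbon. Within the data shown here, the only step of this kind measured in this assay is the one from compound 1 to compound 2, which stayed within the scatter.

On that basis the step from compound 3 to compound 4 in this assay is expected to be small, about a 1.2-fold lower number from compound 3 to compound 4 (0.09 log units; within the scatter), because the related step of a 1.3-fold lower number from compound 1 to compound 2 (0.12 log units; within the scatter) was itself within the scatter. Compound 4 is therefore estimated at 29 ug/mL in this assay, with a range from 14 ug/mL to 55 ug/mL.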

Compound 4, half-maximal cytotoxic concentration: 15 ug/mL
Estimate against measurement, compound 4: 1.9-fold (0.29 log units) above; the range from low to high includes it.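

In this assay, methyl in place of hydrogen on a saturated chain carbon, four bonds along the chain from a carbonyl carbon, gives a 2.4-fold lower number from compound 3 to compound 4 (0.38 log units; beyond the scatter), a modest step that lies beyond the scatter. Set beside the earlier step of this kind, it gives no ground for saying that the size of the change depends on the core: the same change on two cores in this assay, a 1.3-fold lower number (0.12 log units; within the scatter) from compound 1 to compound 2 and a 2.4-fold lower number (0.38 log units; beyond the scatter) from compound 3 to compound 4, 1.8-fold (0.26 log units) apart, within the scatter of two such steps. Among these compounds, this does not show that the two steps are equal or that added methyl lowers the number throughout the series, since only two pairs are at hand, one step stays within the scatter, and the methyl enters at a different place in each pair.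

Still open, from the compounds shown here alone, is whether the number in this assay keeps moving in the same direction with a longer chain, such as hexyl, in place of the chain that carries the change in compound 4. The compounds shown also leave open what an amine or a carboxylic acid on either chain would do to the number in this assay.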